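Moving a Chlorine Around the Ring

A few compounds are considered here, and "the series" means these few. Any claim that something is new, unique, unknown or untested is made for them only; others in the source may bear on it.

Two compounds built on the same core, carrying a 4-hydroxyphenyl group and a furan-2-yl group, were examined in a functional assay on HCT-15 cells (Homo sapiens) for cytotoxicity, read by CCK-8 assay and cell counting, with a stated time of 2 days; on this read-out higher numbers stand for weaker inhibition and lower numbers for stronger inhibition. Compound 1, `Oc1ccc(-c2cc(-c3ccncc3)nc(-c3cccc(Cl)c3)c2)cc1`, has no result in this assay; its entry reads "not determined" (no result reported). Within the data shown here, compound 2, `Oc1ccc(-c2cc(-c3ccc(Cl)cc3)nc(-c3ccco3)c2)cc1`, gives 7020 nM in this assay, and this is the only number available, so compound 2 stands alone with nothing measured to set beside it. Compound 3, `Oc1ccc(-c2cc(-c3cccc(Cl)c3)nc(-c3ccco3)c2)cc1`, has not yet been tested. The change from compound 2 to compound 3 is 3-chlorophenyl in place of 4-chlorophenyl on an aromatic carbon; the two compounds contain the same atoms, joined differently. Among the measured compounds shown here, no pair of measured compounds differing in one place is known here, so the size of this step cannot be read from existing data and has to be judged from the change itself. The change keeps every atom and alters only how they are joined. The expectation is a step that stays within the usual scatter, with no clear direction. Compound 3 is therefore estimated at 7000 nM, with a range from 2500 nM to 20000 nM. This estimate corresponds to an expected step of a 1.0-fold lower number from compound 2 to compound 3 (0.00 log units; within the scatter).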

Compound 3, half-maximal inhibitory concentration: 8020 nM
Compound 3: the middle estimate sits 1.1-fold (0.06 log units) below what was measured; the measured number falls inside the stated range.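

In this assay, among these compounds, the swap of 4-chlorophenyl for 3-chlorophenyl gives a 1.1-fold higher number from compound 2 to compound 3 (0.06 log units; within the scatter) and provides the first step at this position that can be read from measured numbers. In practical terms, compound 2 and compound 3 cannot be told apart on this read-out: moving the chlorine between these two places on the phenyl ring produces no difference that can be separated from the ordinary variation between repeat measurements. Nothing else available here bears on this result.

This single pair speaks only to the place of the chlorine, so it says nothing about what would happen if the chlorine were replaced or if the phenyl ring carried a different group altogether. A carboxylic acid, an amine or a longer carbon chain on that ring might behave quite differently, and whether such groups would move the number beyond the usual scatter remains an open question.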